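The source may hold more compounds than are shown below. What is called first, only, known or untested is meant among the compounds shown, and "the series" means these compounds.

Measured compounds:
- compound 1, `COc1ccc(-c2cc(NC(=S)NNC(=O)c3ccc(C)cc3)cs2)cc1`: 40000 nM
- compound 2, `Cc1ccc(C(=O)NNC(=S)Nc2csc(-c3ccccc3)c2)cc1`: 30000 nM
- compound 3, `COc1ccc(-c2cc(Nc3nnc(-c4ccc(C)cc4)s3)cs2)cc1`: > 100000 nM

In a functional assay on MCF7 cells (Homo sapiens) for inhibition, read by colorimetric assay and MTT assay, with a stated time of 72 h (a lower number here means a stronger inhibitor, a higher number a weaker inhibitor), compound 1 gives 40000 nM and compound 2 gives 30000 nM. The step of a 1.3-fold lower number from compound 1 to compound 2 (0.12 log units; within the scatter) comes from hydrogen in place of methoxy on an aromatic carbon. For compound 3 this assay reports only a limit, > 100000 nM, and that value is a limit of the assay, not a number (the limit of > 100000 nM in this assay, at which 1 of the 3 values shown sits). The difference between the core of compound 1 and the core of compound 3 is not broken down here.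

Compound 4, `Cc1ccc(-c2nnc(Nc3csc(-c4ccccc4)c3)s2)cc1`, is not yet measured. It differs from compound 3 by hydrogen in place of methoxy on an aromatic carbon, the same kind of change as from compound 1 to compound 2. Since that earlier step was within the scatter, the step from compound 3 to compound 4 is expected to be about as small, a step that the limit leaves unreadable from compound 3 to compound 4. Compound 4 is therefore estimated at 150000 nM, with a good chance that this assay again reports only a limit.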

Compound 4, half-maximal inhibitory concentration: 34000 nM
Beside the measured number, compound 4's estimate is 4.4-fold (0.64 log units) above it; the whole stated range lies above it.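

In this assay, the change from 4-methoxyphenyl to phenyl gives an at least 2.9-fold lower number from compound 3 to compound 4 (0.46 log units; beyond the scatter), which lies beyond the scatter, whereas on the other core it gives a 1.3-fold lower number from compound 1 to compound 2 (0.12 log units; within the scatter), which lies within it. Compound 3 has only a limit, > 100000 nM, and not a number. The change therefore has a readable effect on both cores, but the data do not show whether its size carries over from one core to the other: the same change on two cores in this assay, a 1.3-fold lower number (0.12 log units; within the scatter) from compound 1 to compound 2 and an at least 2.9-fold lower number (0.46 log units; beyond the scatter) from compound 3 to compound 4; the limit leaves it open whether they differ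

The compounds shown leave open how a hydroxyl, an amine or a carboxylic acid in place of methoxy would read in this assay. They also leave open how large the step on the core of compound 3 is.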